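Moving the trifluoromethyl group across two hydroxyphenyl pairs

This account rests on a few compounds, and the source may have more. Where it says the series, first, only, none or still open, it means among the compounds named here.

Going by the values given here, compound 1 `Oc1ccccc1-c1cc(-c2ccccc2C(F)(F)F)cc(-c2ccccc2O)n1` is the only compound here with a numerical result in a functional assay on HeLa cells (Homo sapiens) for inhibition (a lower number here means a stronger inhibitor, a higher number a weaker inhibitor), where compound 1 gives 5800 nM. Compound 2 `Oc1ccccc1-c1cc(-c2cccc(C(F)(F)F)c2)cc(-c2ccccc2O)n1` carries 3-(trifluoromethyl)phenyl in place of 2-(trifluoromethyl)phenyl on an aromatic carbon. In this assay compound 2 reaches only the limit > 50000 nM. The change produces an at least 8.6-fold higher number from compound 1 to compound 2 (0.93 log units; beyond the scatter); its size is a lower bound because the limit of > 50000 nM in this assay, at which 2 of the 3 values shown sit, is where compound 2 sits.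

Compound 3 `Oc1ccc(-c2cc(-c3ccccc3C(F)(F)F)cc(-c3ccc(O)cc3)n2)cc1` has the same trifluoromethyl placement as compound 1 but a different core; how the two cores differ is not broken down here. In this assay compound 3 gives only the limit > 50000 nM.

Compound 4 `Oc1ccc(-c2cc(-c3cccc(C(F)(F)F)c3)cc(-c3ccc(O)cc3)n2)cc1` is not yet measured and carries 3-(trifluoromethyl)phenyl in place of 2-(trifluoromethyl)phenyl on an aromatic carbon. This is the same kind of change as from compound 1 to compound 2, with the place meta to two 4-hydroxyphenyl groups here rather than meta to two 2-hydroxyphenyl groups. Resting on an at least 8.6-fold higher number from compound 1 to compound 2 (0.93 log units; beyond the scatter), the step is expected to be about a step that the limit leaves unreadable from compound 3 to compound 4, though starting from a limit it can hardly be resolved. For compound 4 a value of about 200000 nM is estimated in this assay, most likely reported again only as a limit, somewhere between 50000 nM and 1000000 nM.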

Compound 4, half-maximal inhibitory concentration: > 50000 nM
Compound 4 gave a limit, no number; the forecaster's own chance of this, stated with the estimate: 90%; the middle value is on the limit's open side.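

In this assay compound 4 gives > 50000 nM, which is a limit. Compound 3 also stands at a limit, so no step from compound 3 to compound 4 can be read: the limit of > 50000 nM in this assay, at which 3 of the 4 values shown sit.

The compounds shown leave open whether 3-(trifluoromethyl)phenyl in place of 2-(trifluoromethyl)phenyl changes inhibition at all when the two 4-hydroxyphenyl groups are present.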